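The source may report more compounds than this note shows. Statements on the series, on what has been measured and on what is new or still open speak of the compounds shown alone.

Series notes, compound 1 onward.

The shared core is that of compound 1 `O=c1cc(/C=N\Nc2ccc([N+](=O)[O-])cc2)c2ccc(OCc3ccccc3)cc2o1`, carrying a benzyloxy group and a hydrazone linked to a 4-nitrophenyl ring. In a functional assay, read by spectrophotometry, with a stated time of 1 h (a lower number here means a stronger inhibitor, a higher number a weaker inhibitor), compound 1 gives only a limit, > 2000000 nM; this is the limit noted as the limit of > 2000000 nM in this assay, at which 1 of the 3 values shown sits, and no number sits behind it. Two measured neighbours exist. Compound 2 `O=c1cc(/C=N\Nc2ccc([N+](=O)[O-])cc2[N+](=O)[O-])c2ccc(OCc3ccccc3)cc2o1` adds a second nitro group and in this assay compound 2 gives 1970000 nM, a step of an at least 1.0-fold lower number from compound 1 to compound 2 (0.00 log units; that floor lies within the scatter). Compound 3 `O=c1cc(/C=N\Nc2ccc([N+](=O)[O-])cc2)c2c(OCc3ccccc3)cc(OCc3ccccc3)cc2o1` adds a second benzyloxy group and in this assay compound 3 gives 97900 nM, a step of an at least 20-fold lower number from compound 1 to compound 3 (1.31 log units; beyond the scatter).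

Compound 4 `O=c1cc(/C=N\c2ccccc2O)c2ccc(OCc3ccccc3)cc2o1` is not yet measured. It differs from compound 1 by 2-hydroxyphenyl in place of (4-nitrophenyl)amino on a double-bonded nitrogen. Neither measured step touches the hydrazone end, so neither bears on this change directly; both show a core that sits at or near the limit whatever is done to it. For compound 4 a change of an at least 1.3-fold lower number from compound 1 to compound 4 (0.12 log units; that floor lies within the scatter) is expected, with the chance that only a limit is returned again. The expected value for compound 4 in this assay is 1500000 nM, within a range of 300000 nM to 6000000 nM.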

Compound 4, half-maximal inhibitory concentration: "not active" (no number reported)
For compound 4 the study gives words and no number; the estimate stays without a comparison.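

In this assay, for the compounds shown here, compound 4 is reported only in words, as not active, so no step from compound 1 to compound 4 can be read. Compound 1 gives only a limit: the limit of > 2000000 nM in this assay, at which 1 of the 4 values shown sits.

From the compounds shown here alone, how far 2-hydroxyphenyl in place of (4-nitrophenyl)amino shifts the number in this assay remains open.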